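The source may hold more compounds than are shown below. What is called first, only, known or untested is meant among the compounds shown, and "the series" means these compounds.

Compound 3 `CC(C)(C)N(NC(=O)c1cccc(Br)c1)C(=O)c1ccccc1Cl` gives 191 nM in an assay on cells for agonist activity at ecdysone receptor (Bombyx mori), read by a luciferase reporter, with a stated time of 24 h (a lower number here means that less compound is needed, a higher number that more compound is needed for the effect), the second highest of the three numbers measured. Compound 2 `CC(C)(C)N(NC(=O)c1cccc(Cl)c1)C(=O)c1ccccc1Cl` gives 155 nM; the step of a 1.2-fold higher number from compound 2 to compound 3 (0.09 log units; within the scatter) is within the scatter. Compound 1 `CC(C)(C)N(NC(=O)c1ccccc1I)C(=O)c1ccccc1Cl` gives 1290 nM, and the steps of an 8.3-fold lower number from compound 1 to compound 2 (0.92 log units; beyond the scatter) and a 6.8-fold lower number from compound 1 to compound 3 (0.83 log units; beyond the scatter) are the only ones beyond the scatter, both involving a change of the ring position as well as the halogen.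

Compound 4 `Cc1cccc(C(=O)NN(C(=O)c2ccccc2Cl)C(C)(C)C)c1` differs from compound 3 by methyl in place of bromo on an aromatic carbon. For the measured compounds named here, no measured step exchanges a halogen for methyl on this ring; the one step at this position, a 1.2-fold higher number from compound 2 to compound 3 (0.09 log units; within the scatter), is small. The expected step is therefore a 1.4-fold higher number from compound 3 to compound 4 (0.13 log units; within the scatter), close to the scatter. Compound 4 is estimated at 260 nM, with a range of 100 nM to 650 nM.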

Compound 4, half-maximal effective concentration: 603 nM
Estimate against measurement, compound 4: 2.3-fold (0.37 log units) below, and the stated range covers the measured number.
By their numbers in this assay, from the lowest: compounds 2 and 3 (each within the scatter of the next); then compound 4; then compound 1.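

Replacing a halogen with methyl at this place moves the number, unlike the exchange of bromo for chloro: a 3.2-fold higher number from compound 3 to compound 4 (0.50 log units; beyond the scatter) and a 3.9-fold higher number from compound 2 to compound 4 (0.59 log units; beyond the scatter) are both beyond the scatter. So chloro and bromo cannot stand for every small group here. The loss is partial, since a 2.1-fold lower number from compound 1 to compound 4 (0.33 log units; beyond the scatter) is also beyond the scatter, which leaves compound 4 between the halogen pair and compound 1.

From the compounds shown here alone, it remains open how methoxy, an amine or a carboxylic acid would compare in this place. No available measurement accounts for the gap between methyl and the two halogens.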